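The compounds below may be only part of what the source reports. "The series", "measured", "known", "first", "only" and "open" are said of these compounds alone.

Measured compounds:
Compound 1, `COc1ccc(C2(NC(=O)c3c(OC)cc(C(F)(F)F)cc3SC)CCCN(C)C2)cc1`, gives 170 nM in an assay on cells for inhibition of sodium- and chloride-dependent glycine transporter 1 (Homo sapiens); a higher number here means that more compound is needed for the effect, a lower number that less compound is needed.
Compound 2, `COc1cc(C(F)(F)F)cc(SC)c1C(=O)NC1(c2cccc(F)c2)CCCN(C)C1`, gives 48 nM in this assay.
Compound 3, `COc1cc(C(F)(F)F)cc(SC)c1C(=O)NC1(c2cccc(Cl)c2)CCCN(C)C1`, gives 25 nM in this assay.

Compound 3 has the lowest of the three numbers, but its gap to compound 2, a 1.9-fold lower number from compound 2 to compound 3 (0.28 log units; within the scatter), lies within the scatter, so the two cannot be ordered. Its gap to compound 1, a 6.8-fold lower number from compound 1 to compound 3 (0.83 log units; beyond the scatter), is beyond the scatter, as is the step of a 3.5-fold lower number from compound 1 to compound 2 (0.55 log units; beyond the scatter). The aryl group on the saturated ring carbon therefore does move the number in this assay, at least when a 4-methoxyphenyl is exchanged for a halophenyl.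

Compound 4, `COc1cc(C(F)(F)F)cc(SC)c1C(=O)NC1(c2ccncc2)CCCN(C)C1`, carries a different exchange: pyridin-4-yl in place of 3-chlorophenyl on a saturated ring carbon. Going by the values given here, no measured step covers a pyridin-4-yl at this position, and no measured step covers the removal of a halogen from the phenyl ring. The two steps that bear on it only show that the aryl group matters, with changes of modest size. A step of modest size in this assay, towards a higher number, is expected, a 3.6-fold higher number from compound 3 to compound 4 (0.56 log units; beyond the scatter), with wide uncertainty. Compound 4 is estimated at 90 nM, within a range from 30 nM to 300 nM.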

Compound 4, half-maximal effective concentration: 60 nM
Compound 4: the middle estimate sits 1.5-fold (0.18 log units) above what was measured; the range from low to high includes it.
By their numbers in this assay, from the lowest: compounds 3, 2 and 4 (each within the scatter of the next, the first and the last beyond it); then compound 1.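

The saturated ring carbon accepts an aromatic ring containing nitrogen as well as a halophenyl: in this assay, pyridin-4-yl in place of 3-chlorophenyl gives a 2.4-fold higher number from compound 3 to compound 4 (0.38 log units; beyond the scatter) and is a modest step, whereas pyridin-4-yl in place of 3-fluorophenyl gives a 1.3-fold higher number from compound 2 to compound 4 (0.10 log units; within the scatter) and leaves those two compounds unordered. A halogen on the aromatic ring is therefore not needed at this position to reach the range of the fluoro compound, and the gain over the 4-methoxyphenyl compound also survives without one, with pyridin-4-yl in its place giving a 2.8-fold lower number from compound 1 to compound 4 (0.45 log units; beyond the scatter) as another modest step. The compounds shown offer no measurement that would explain these differences among the aryl groups.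

Still open, on these data alone, is how a pyridin-3-yl or a pyridin-2-yl would behave on this ring carbon, which would show whether the place of the ring nitrogen in the aromatic ring matters. An unsubstituted phenyl, a 3-methoxyphenyl and a 4-chlorophenyl are also absent from the set, so the effect of the methoxy group cannot be separated from that of its place on the phenyl ring.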